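Trifluoromethyl in Place of Fluoro, Seen a Second Time

The source may report more compounds than this note shows. Statements on the series, on what has been measured and on what is new or still open speak of the compounds shown alone.

Compound 1 `O=C(Nc1ccc2c(c1)B(O)OC2)c1ccc(C(F)(F)F)cc1F` and compound 3 `O=C(Nc1ccc2c(c1)B(O)OC2)c1ccc(C(F)(F)F)cc1C(F)(F)F` share a core and differ in one spot: trifluoromethyl in place of fluoro on an aromatic carbon. In a functional assay on PBMC cells (Homo sapiens) for inhibition, read by HTRF, with stated times of 15 min and 24 h (on this read-out lower numbers stand for stronger inhibition and higher numbers for weaker inhibition), compound 1 gives > 100000 nM, which is a limit of the assay rather than a number. Compound 3 gives 5300 nM in this assay, so the change brought an at least 18-fold lower number from compound 1 to compound 3 (1.27 log units; beyond the scatter). Compound 2 `O=C(Nc1ccc2c(c1)B(O)OC2)c1cc(C(F)(F)F)ccc1F` holds the same atoms as compound 1 joined differently; the difference between the two cores is not broken down here. In this assay compound 2 gives > 100000 nM, again a limit rather than a number, the point where (the limit of > 100000 nM in this assay, at which 2 of the 3 values shown sit). Compound 4 `O=C(Nc1ccc2c(c1)B(O)OC2)c1cc(C(F)(F)F)ccc1C(F)(F)F` stands to compound 2 as compound 3 stands to compound 1, through the same kind of change: trifluoromethyl in place of fluoro on an aromatic carbon. The surroundings differ, the new group being para to a trifluoromethyl group in compound 4 where in compound 3 it is meta to a trifluoromethyl group. Because the same change earlier gave an at least 18-fold lower number from compound 1 to compound 3 (1.27 log units; beyond the scatter), compound 4 is expected to show an at least 12-fold lower number from compound 2 to compound 4 (1.09 log units; beyond the scatter), the limit of compound 2 leaving the true size open. Compound 4 is accordingly estimated at 8000 nM, within 2000 nM to 40000 nM.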

Compound 4, half-maximal inhibitory concentration: 2000 nM
Compound 4: middle estimate off by 4.0-fold (0.60 log units), on the high side; the range from low to high includes it.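

Carried to the second core, trifluoromethyl in place of fluoro again gave a lower number in this assay, with an at least 50-fold lower number from compound 2 to compound 4 (1.69 log units; beyond the scatter), and set beside the earlier case the two steps read as follows: the same change on two cores in this assay, an at least 18-fold lower number (1.27 log units; beyond the scatter) from compound 1 to compound 3 and an at least 50-fold lower number (1.69 log units; beyond the scatter) from compound 2 to compound 4; the limit leaves it open whether they differ The direction of the change therefore holds on both cores shown, and neither pair goes against it, but two pairs make no rule for the wider series. The true size of each step stays unknown, since each one starts from a limit of the assay rather than a number: the limit of > 100000 nM in this assay, at which 2 of the 4 values shown sit.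

The compounds shown carry only fluoro or trifluoromethyl at this place, which leaves open how a nitrile, a methoxy group or an amine there would read in this assay. They also leave open whether the same change would carry over to a core bearing a carboxylic acid or a longer chain elsewhere on the molecule.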